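The source may hold more compounds than are shown below. What is called first, only, known or untested is meant among the compounds shown, and "the series" means these compounds.

The measured compounds and their values in an ADME assay on microsomes from liver (Homo sapiens) for metabolic stability, tested at 2.5 uM; a higher number here means faster removal of the compound, a lower number slower removal:
compound 1 `COc1ccc(S(=O)(=O)c2cnc3c(F)cccc3c2-c2cccc(F)c2)cc1` gives 3.03 mL/min;
compound 2 `COc1ccc(S(=O)(=O)c2cnc3c(F)cccc3c2-c2cccc(Cl)c2)cc1` gives 2.75 mL/min;
compound 3 `COc1ccc(S(=O)(=O)c2cnc3c(F)cccc3c2-c2cccc(OC)c2)cc1` gives 2.87 mL/min.

Compound 1 holds the highest of the three numbers, though the gaps are slight: the steps of a 1.1-fold lower number from compound 1 to compound 2 (0.04 log units; within the scatter) and a 1.1-fold lower number from compound 1 to compound 3 (0.02 log units; within the scatter) both lie within the scatter, as does a 1.0-fold higher number from compound 2 to compound 3 (0.02 log units; within the scatter). Compound 4 `Cc1ccc(S(=O)(=O)c2cnc3c(F)cccc3c2-c2cccc(F)c2)cc1F` differs from compound 1 by 3-fluoro-4-methylphenyl in place of 4-methoxyphenyl on a sulfonyl sulfur. Among the measured compounds shown here, all three measured steps exchange a group on another ring, not on the sulfonyl sulfur, so none bears directly on this change; what they show is only that the series so far varies little. Compound 4 is therefore expected to land near compound 1. For compound 4 the expected step is a 1.0-fold lower number from compound 1 to compound 4 (0.02 log units; within the scatter). Compound 4 is estimated at 2.9 mL/min, with a range from 1.5 mL/min to 5.6 mL/min.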

Compound 4, intrinsic clearance in a liver preparation (reported as CLH), per the amount of preparation that the assay uses: 3.92 mL/min
The estimate for compound 4 lay 1.4-fold (0.13 log units) below the measured number, within the range that was stated.
By their numbers in this assay, from the lowest: compounds 2, 3, 1 and 4 (each within the scatter of the next).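

Among the compounds shown here, the first change on the sulfonyl sulfur, 3-fluoro-4-methylphenyl in place of 4-methoxyphenyl, gives in this assay a 1.3-fold higher number from compound 1 to compound 4 (0.11 log units; within the scatter). So this position, like the ring varied earlier, has not yet moved the number beyond the scatter in the one exchange shown. Nothing at hand speaks to the reason for this result.

On these data alone, whether a phenyl ring bearing an amine or a carboxylic acid on the sulfonyl sulfur would go beyond the scatter remains open. So does whether this exchange would read the same with chloro or methoxy on the other ring.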